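Swapping a Pyrazole for a Methylsulfonyl Group

This account rests on a few compounds, and the source may have more. Where it says the series, first, only, none or still open, it means among the compounds named here.

Compound 1: `CNc1nc(NCCCN(C)C)c2sc(-c3ccc(-n4cccn4)cc3)cc2n1` — 217 ug/mL
Compound 2: `CNc1nc(NCCCN(C)C)c2sc(-c3ccc(OC)nc3)cc2n1` — > 100 ug/mL

In a physicochemical assay for solubility, at pH 2 (on this read-out lower numbers stand for lower solubility and higher numbers for higher solubility), compound 1 gives 217 ug/mL. Among the measured compounds shown here, this is the only plain number in the set. Compound 2 gives > 100 ug/mL, which is a limit of the assay rather than a number, as shown by the limit of > 100 ug/mL in this assay, at which 1 of the 2 values shown sits. Compound 3, `CNc1nc(NCCCN(C)C)c2sc(-c3ccc(S(C)(=O)=O)cc3)cc2n1`, has not been measured. It differs from compound 1 in one place: methylsulfonyl in place of 1H-pyrazol-1-yl on an aromatic carbon. For the measured compounds named here, no step between two measured compounds is available to guide an expectation, so the change from compound 1 to compound 3 is expected to stay within the usual scatter, with a 1.1-fold lower number from compound 1 to compound 3 (0.04 log units; within the scatter). Compound 3 is estimated at 200 ug/mL, between 80 ug/mL and 500 ug/mL.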

Compound 3, solubility: > 100 ug/mL
Compound 3 was reported as a limit; the forecaster's own chance of this, stated with the estimate: 30%; the middle value lies beyond the limit too.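

Compound 3 gives > 100 ug/mL, which is a limit and not a number, so no step from compound 1 to compound 3 can be read: the limit of > 100 ug/mL in this assay, at which 2 of the 3 values shown sit.

On these data alone, whether methylsulfonyl in place of 1H-pyrazol-1-yl on an aromatic carbon shifts the number in this assay stays open.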